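The source may hold more compounds than are shown below. What is called first, only, known or untested is meant among the compounds shown, and "the series" means these compounds.

Measured in a functional assay on HCT-116 cells (Homo sapiens) for antiproliferative activity, read by luminescence, with a stated time of 72 h (on this read-out lower numbers stand for stronger inhibition and higher numbers for weaker inhibition), so far:
compound 1 `CN1CC2(CC(=O)c3cc(/C=C/C(=O)NO)ccc3O2)C1` gives 178 nM
compound 2 `CC(=O)N1CC2(CC(=O)c3cc(/C=C/C(=O)NO)ccc3O2)C1` gives 10500 nM
compound 3 `O=C(/C=C/c1ccc2c(c1)C(=O)CC1(CN(Cc3ccccc3)C1)O2)NO` gives 76 nM

Compound 1 stands second highest of these three numbers, with compound 3 nearest and compound 2 furthest. The change to compound 4 `O=C(/C=C/c1ccc2c(c1)C(=O)CC1(CN(Cc3ccc(F)cc3)C1)O2)NO` is 4-fluorophenyl in place of hydrogen on a saturated chain carbon bound to an amine nitrogen in a ring. Among the measured compounds shown here, the closest precedent is the modest step of a 2.3-fold lower number from compound 1 to compound 3 (0.37 log units; beyond the scatter) with phenyl entering at the same place. The large steps of a 59-fold higher number from compound 1 to compound 2 (1.77 log units; beyond the scatter) and a 140-fold lower number from compound 2 to compound 3 (2.14 log units; beyond the scatter) involve acetyl and bear less directly. For the measured compounds named here, no measured compound carries the fluorine. A modest step to a lower number is expected in this assay (estimated step: a 2.5-fold lower number from compound 1 to compound 4 (0.41 log units; beyond the scatter)). Compound 4 is expected at 70 nM (estimated range: 30 nM to 180 nM).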

Compound 4, half-maximal inhibitory concentration: 190 nM
Estimate against measurement, compound 4: 2.7-fold (0.43 log units) below; measured number outside the range, above it.
By their numbers in this assay, from the lowest: compound 3; then compounds 1 and 4 (each within the scatter of the next); then compound 2.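

In this assay, 4-fluorobenzyl in place of methyl on the ring amine nitrogen gives a 1.1-fold higher number from compound 1 to compound 4 (0.03 log units; within the scatter) and so does not keep the gain seen with benzyl. Fluoro in place of hydrogen on an aromatic carbon alone gives a 2.5-fold higher number from compound 3 to compound 4 (0.40 log units; beyond the scatter) and shows that this substituent responds to a single atom change. Even so, 4-fluorobenzyl in place of acetyl gives a 55-fold lower number from compound 2 to compound 4 (1.74 log units; beyond the scatter) and leaves the acetyl compound well apart.

From the compounds shown here alone, whether chloro or methoxy would behave like fluoro remains open. Nothing available accounts for the effect of the fluorine.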